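Allyl to 2-Bromobenzyl: Expected Cytotoxicity of Compound 4

The source may hold more compounds than are shown below. What is called first, only, known or untested is meant among the compounds shown, and "the series" means these compounds.

Compound 1 `C=CCN1C(=O)N(Cc2ccccc2)S(=O)(=O)n2cccc21` gives > 802000 nM in an ADME assay on MT4 cells (Homo sapiens) for cytotoxicity, read by MTT assay, with a stated time of 5 days; on this read-out lower numbers stand for higher toxicity in this test and higher numbers for lower toxicity in this test; this is a limit of the assay.
Compound 2 `O=C1N(Cc2cccc(Cl)c2)c2cccn2S(=O)(=O)N1Cc1cccc(F)c1` gives 208000 nM in this assay.
Compound 3 `O=C1N(Cc2ccc(Cl)cc2Cl)c2cccn2S(=O)(=O)N1Cc1cccc(Br)c1` gives > 243000 nM in this assay; this is also a limit of the assay.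

Compound 1 therefore has no number of its own, only (the limit of > 802000 nM in this assay, at which 1 of the 3 values shown sits), and compound 3 sits at the limit of > 243000 nM in this assay, at which 1 of the 3 values shown sits. Only compound 2 carries a measured number. Compound 4 `O=C1N(Cc2ccccc2Br)c2cccn2S(=O)(=O)N1Cc1ccccc1` differs from compound 1 by 2-bromophenyl in place of vinyl on a saturated chain carbon bound to an amide-type nitrogen in a ring. Within the data shown here, no measured step between two compounds covers this change, so the expected size rests on compound 2, which bears two benzyl groups and gives 208000 nM. A downward move beyond the scatter in this assay is expected, which the estimated step of an at least 3.2-fold lower number from compound 1 to compound 4 (0.50 log units; beyond the scatter) expresses. Compound 4 is expected to give 250000 nM, within 100000 nM to 800000 nM.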

Compound 4, half-maximal cytotoxic concentration: 226000 nM
Compound 4: middle estimate off by 1.1-fold (0.04 log units), on the high side; the range from low to high includes it.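

Compounds 1 and 4 are the first pair shown that differ in only one place, so allyl to 2-bromobenzyl can now be read alone in this assay. The change gives an at least 3.5-fold lower number from compound 1 to compound 4 (0.55 log units; beyond the scatter). Compound 1 has only a limit, so the full size of this step stays unknown: the limit of > 802000 nM in this assay, at which 1 of the 4 values shown sits.

The compounds shown leave open whether the aromatic ring or its bromine accounts for the step. Also open, on these data alone, is how an amine or a carboxylic acid would read at this place.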